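The source may hold more compounds than are shown below. What is called first, only, known or untested is meant among the compounds shown, and "the series" means these compounds.

Measured in a functional assay on KYSE-70 cells for antiproliferative activity against KYSE-70 cell line (Homo sapiens), read by MTT assay, with a stated time of 72 h; a higher number here means a weaker inhibitor, a lower number a stronger inhibitor:
- compound 1 `O=C(Nc1cccc(F)c1)c1cc(=O)[nH]c2cc(Br)ccc12`: 8900 nM
- compound 2 `O=C(Nc1cccc(OC(F)(F)F)c1)c1cc(=O)[nH]c2cc(Br)ccc12`: > 20000 nM (a limit)
- compound 3 `O=C(Nc1cccc(F)c1)c1cc(=O)[nH]c2cc(-c3ccccc3)ccc12`: > 20000 nM (a limit)

Compound 3 gives > 20000 nM, which is a limit and not a number. This is the limit of > 20000 nM in this assay, at which 2 of the 3 values shown sit. Compound 4 `O=C(Nc1cccc(F)c1)c1cc(=O)[nH]c2cc(-c3ccc(F)cc3)ccc12` carries fluoro in place of hydrogen on an aromatic carbon, turning phenyl to 4-fluorophenyl: fluoro in place of hydrogen on an aromatic carbon.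

Within the data shown here, two measured steps bear on this only loosely. Phenyl in place of bromo gave an at least 2.2-fold higher number from compound 1 to compound 3 (0.35 log units; beyond the scatter), and trifluoromethoxy in place of fluoro gave an at least 2.2-fold higher number from compound 1 to compound 2 (0.35 log units; beyond the scatter). Neither adds fluoro to a phenyl, so no step beyond the scatter is expected in this assay, in either direction. The expected step is a step that the limit leaves unreadable from compound 3 to compound 4. Compound 4 is estimated at 22000 nM, with an expected range of 10000 nM to 50000 nM.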

Compound 4, half-maximal inhibitory concentration: 3300 nM
Estimate against measurement, compound 4: 6.7-fold (0.82 log units) above, outside the stated range (below it).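

In this assay, fluoro in place of hydrogen on the phenyl gives an at least 6.0-fold lower number from compound 3 to compound 4 (0.78 log units; beyond the scatter). Compound 3 stands at > 20000 nM, which is a limit and not a number, so this step has no exact size. A ring at this position is therefore not in itself a loss against bromo, since 4-fluorophenyl in place of bromo gives a 2.7-fold lower number from compound 1 to compound 4 (0.43 log units; beyond the scatter).

Going by these compounds, what a chloro, a methoxy or an amine would do in place of this fluoro stays open. So does whether fluoro elsewhere on the phenyl would give a similar step.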